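Dichlorophenyl change on the oxygen-containing core

The compounds below may be only part of what the source reports. "The series", "measured", "known", "first", "only" and "open" are said of these compounds alone.

Values in a functional assay on A549 cells (Homo sapiens) for antiproliferative activity, read by MTT assay, with a stated time of 72 h (on this read-out higher numbers stand for weaker inhibition and lower numbers for stronger inhibition), for the measured compounds
compound 1 `NC1=NC2(CCOCC2)N(OCCCOc2ccccc2)C(N)=N1` gives 1080 nM
compound 2 `NC1=NC2(CCOCC2)N(OCCCOc2ccccc2Cl)C(N)=N1` gives 2700 nM
compound 3 `NC1=NC2(CCSCC2)N(OCCCOc2cccc(Cl)c2Cl)C(N)=N1` gives 1 nM

Compound 2 at 2700 nM has the highest number of the three in this assay and stands beyond the scatter from both others, with compound 1 the nearest. The next structure is compound 4 `NC1=NC2(CCOCC2)N(OCCCOc2ccc(Cl)c(Cl)c2)C(N)=N1` with 3,4-dichlorophenyl in place of 2-chlorophenyl on an oxygen on a saturated carbon and with the core of compound 2 unchanged. One measured single-place step bears on this: a 2.5-fold higher number from compound 1 to compound 2 (0.40 log units; beyond the scatter) for chloro in place of hydrogen on an aromatic carbon, a modest step beyond the scatter. Compound 4 no longer carries the 2-chlorophenyl group of that step, which points back towards compound 1 at 1080 nM as a first reading. Within the data shown here, no measured compound shows 3,4-dichlorophenyl on this core. Compound 3 at 1 nM is far lower and also holds a dichlorophenyl group, but its core differs too, so it offers only weak support for a larger fall. A modest move to a lower number is therefore expected, with wide uncertainty. The estimate amounts to a 3.4-fold lower number from compound 2 to compound 4 (0.53 log units; beyond the scatter) as an expected step. For compound 4 the estimated value is 800 nM (expected range 120 nM to 3500 nM) in this assay when measured.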

Compound 4, half-maximal inhibitory concentration: 790 nM
Estimate against measurement, compound 4: 1.0-fold (0.01 log units) above; low and high end bracket the measured number.
By their numbers in this assay, from the lowest: compound 3; then compounds 4 and 1 (each within the scatter of the next); then compound 2.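

In this assay, among these compounds, the change at this place, on an oxygen on a saturated carbon, gives a 3.4-fold lower number from compound 2 to compound 4 (0.53 log units; beyond the scatter), so the aryl group here can move the number in either direction on the shared core, not only in the direction of the single chloro step, a 2.5-fold higher number from compound 1 to compound 2 (0.40 log units; beyond the scatter). Against the unsubstituted group, 3,4-dichlorophenyl gives a 1.4-fold lower number from compound 1 to compound 4 (0.14 log units; within the scatter), which lies within the scatter, so on this core two chlorines in this arrangement read the same as phenyl, while one chlorine as 2-chlorophenyl stands apart from both, and the chlorine count alone does not set the number. No measurement at hand gives a reason for this difference between the two chlorinated groups.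

On these data alone, compound 4 and compound 3 differ in both the core and the aryl group, so compound 3 at 1 nM cannot be divided between those two places, and it remains open how much of that value belongs to each. Also open, as far as these compounds go, is how this place responds to groups of another kind, such as an amine or a carboxylic acid on the phenyl ring, or to a longer chain carrying it.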